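This account rests on a few compounds, and the source may have more. Where it says the series, first, only, none or still open, it means among the compounds named here.

Compound 2 `O=C(Nc1ccc(Sc2nc3ccccc3s2)cc1)c1ccccc1O` is tested in an ADME assay on HEK293 cells (Homo sapiens) for cytotoxicity, read by reporter gene assay and resazurin assay, with a stated time of 48 h (a higher number here means that more compound is tolerated, a lower number that less compound is tolerated), where compound 2 gives 74000 nM. Of the two numbers recorded in this assay, compound 2 has the higher one; its nearest neighbour is compound 1 `O=C(Nc1ccc(Sc2nc3ccccc3s2)c(Cl)c1)c1ccccc1O`, which in this assay gives 64000 nM. The change from compound 1 to compound 2, hydrogen in place of chloro on an aromatic carbon, gives a 1.2-fold higher number from compound 1 to compound 2 (0.06 log units; within the scatter). Compound 3 `COc1c(Br)cc(Br)cc1C(=O)Nc1ccc(Sc2nc3ccccc3s2)cc1` is reported only as a limit of the assay, > 100000 nM, which corresponds to the limit of > 100000 nM in this assay, at which 1 of the 3 values shown sits.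

The unmeasured compound 4 `O=C(Nc1ccc(Sc2nc3ccccc3s2)cc1)c1cccc(Br)c1` differs from compound 2 in one place: 3-bromophenyl in place of 2-hydroxyphenyl on a carbonyl carbon. For the measured compounds named here, no measured step swaps the ring on the carbonyl carbon; the single step available, from compound 1 to compound 2, changes a different ring and stays within the scatter. Compound 4 is therefore expected to sit close to compound 2, with the estimated step of a 1.1-fold lower number from compound 2 to compound 4 (0.02 log units; within the scatter) not beyond the scatter. The estimate for compound 4 in this assay is 70000 nM, with a range from 30000 nM to 150000 nM.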

Compound 4, half-maximal cytotoxic concentration: 74000 nM
Compound 4: middle estimate off by 1.1-fold (0.02 log units), on the low side, within the range that was stated.
By their numbers in this assay, from the lowest: compounds 1, 2 and 4 (each within the scatter of the next). At a limit, above all of these: compound 3.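

The earlier step changed a different ring, whereas this one changes the ring on the carbonyl carbon, and in this assay replacing 2-hydroxyphenyl with 3-bromophenyl gives no change at the digits printed from compound 2 to compound 4 (within the scatter). This single exchange removes the oxygen, with its hydrogen-bond donor and acceptor, and brings in a bromine, so within this pair the number does not depend on keeping that oxygen. Nothing shown gives a reason for this result.

From the compounds shown here alone, it remains open whether a ring carrying an amine or a carboxylic acid, or a longer chain in place of the ring, would leave the number just as unmoved at this carbonyl carbon. The loss of the hydroxy group and the gain of the bromine also remain unseparated, with no compound shown carrying a plain phenyl here.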